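The source may hold more compounds than are shown below. What is called first, only, known or untested is meant among the compounds shown, and "the series" means these compounds.

In an assay on isolated protein for inhibition of hexokinase-1 (Rattus norvegicus), with a stated time of 6 h, tested at 10 mM (a lower number here means less inhibition, a higher number more inhibition at the concentration tested (going by the name of the read-out)), compound 3 `O=C(CI)NCCCCCCCNc1ncnc2c1ncn2[C@@H]1O[C@H](COP(=O)(O)OP(=O)(O)OP(=O)(O)O)[C@@H](O)[C@H]1O` gives 20%, the highest of the three numbers recorded. Compound 1 `O=C(CI)NCCC(=O)NCCCCCCNc1ncnc2c1ncn2[C@@H]1O[C@H](COP(=O)(O)OP(=O)(O)OP(=O)(O)O)[C@@H](O)[C@H]1O` gives 0%, and compound 2 `O=C(CI)NCCNc1ncnc2c1ncn2[C@@H]1O[C@H](COP(=O)(O)OP(=O)(O)OP(=O)(O)O)[C@@H](O)[C@H]1O` gives 0%. The two steps that lead to compound 3, a number 20 percentage points higher from compound 1 to compound 3 (beyond the scatter) and a number 20 percentage points higher from compound 2 to compound 3 (beyond the scatter), are both changes of the chain that carries the ((iodomethyl)carbonyl)amino group, not of that group itself. Compound 4 `CC(=O)NCCCCCCCCNc1ncnc2c1ncn2[C@@H]1O[C@H](COP(=O)(O)OP(=O)(O)OP(=O)(O)O)[C@@H](O)[C@H]1O` differs from compound 3 in another way: acetamidomethyl in place of ((iodomethyl)carbonyl)amino on a saturated chain carbon, seven bonds along the chain from a nitrogen on an aromatic ring. Among the compounds with values here, no measured step exchanges this group while keeping the chain, so the measured steps bear on the change only loosely. A drop beyond the scatter is nevertheless expected, a number 15 percentage points lower from compound 3 to compound 4 (beyond the scatter). For compound 4 the estimate is 5%, within 0% to 20%.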

Compound 4, a percentage reported as inhibition, at one concentration (the size of the read-out at that concentration, not a potency): 0%
Estimate against measurement, compound 4: 5 percentage points above, within the range that was stated.
By their numbers in this assay, from the lowest: compounds 1, 2 and 4 (each within the scatter of the next); then compound 3.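

In this assay, within the data shown here, exchanging ((iodomethyl)carbonyl)amino for acetamidomethyl, seven bonds along the chain from a nitrogen on an aromatic ring, gives a number 20 percentage points lower from compound 3 to compound 4 (beyond the scatter) as the first measured step that replaces this group. The other two comparisons give no change at the digits printed from compound 2 to compound 4 (within the scatter) and no change at the digits printed from compound 1 to compound 4 (within the scatter) for the new compound, so among these four only compound 3 reads above the rest. No evidence is available on what lies behind this drop. Still open, going by these compounds, is how a chloroacetamide or bromoacetamide would read on the chain of compound 3, and whether a longer chain carrying ((iodomethyl)carbonyl)amino would keep or change the reading.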